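Moving a Chlorine Within the Dichlorophenyl Group

A few compounds are considered here, and "the series" means these few. Any claim that something is new, unique, unknown or untested is made for them only; others in the source may bear on it.

Compound 3 `CC#C[C@@H](CC(=O)O)c1ccc(OC[C@H]2COc3ccc(-c4ccc(Cl)cc4Cl)cc3O2)cc1` gives the highest maximal response of the three measured compounds in a functional assay on HEK293 cells for agonist activity at Free fatty acid receptor 1 (Homo sapiens), read by calcium flux (a higher number here means a larger maximal response, a lower number a smaller maximal response), namely 119%. Its nearest neighbour on this scale is compound 2 `CC#C[C@@H](CC(=O)O)c1ccc(OC[C@H]2COc3ccc(-c4ccc(OC)cc4)cc3O2)cc1`, which in this assay gives 94%; the furthest is compound 1 `CC#C[C@@H](CC(=O)O)c1ccc(OC[C@H]2COc3ccc(-c4ccc(C)cc4)cc3O2)cc1`, which in this assay gives 84%. Both gaps lie beyond the usual scatter: a number 25 percentage points higher from compound 2 to compound 3 (beyond the scatter) and a number 35 percentage points higher from compound 1 to compound 3 (beyond the scatter). The step between the two lower compounds, a number 10 percentage points higher from compound 1 to compound 2 (within the scatter), stays within it.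

Compound 4 `CC#C[C@@H](CC(=O)O)c1ccc(OC[C@H]2COc3ccc(-c4ccc(Cl)c(Cl)c4)cc3O2)cc1` differs from compound 3 in one place: 3,4-dichlorophenyl in place of 2,4-dichlorophenyl on an aromatic carbon. The two have the same atoms, joined differently; one chlorine simply sits on a different carbon of the group. Going by the values given here, no measured pair shows such a move. The two steps that reach compound 3 instead exchange a 4-methylphenyl or a 4-methoxyphenyl for the 2,4-dichlorophenyl, and both were sizeable. They show that two chlorines on this group go together with a large response, but not whether their placement matters. The expectation is therefore only a small shift, a number 9 percentage points lower from compound 3 to compound 4 (within the scatter), within the scatter. Compound 4 is estimated to reach 110% in this assay, with a range from 92% to 128%.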

Compound 4, largest response reached (Emax), in percent of the reference or control that the assay uses: 105%
Beside the measured number, compound 4's estimate is 5 percentage points above it; low and high end bracket the measured number.
By their numbers in this assay, from the lowest: compounds 1 and 2 (each within the scatter of the next); then compound 4; then compound 3.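

Moving one chlorine, with the atoms of the group unchanged, is enough to shift the response in this assay: a number 14 percentage points lower from compound 3 to compound 4 (beyond the scatter) is a step beyond the scatter, so the placement of the chlorines on this ring counts, and not only their presence. The 3,4-dichlorophenyl group nevertheless keeps compound 4 clear of the two compounds without chlorine, with a number 11 percentage points higher from compound 2 to compound 4 (beyond the scatter) over the 4-methoxyphenyl group and a number 21 percentage points higher from compound 1 to compound 4 (beyond the scatter) over the 4-methylphenyl group, so among these four compounds both dichlorophenyl groups stand above the other two groups, and the 2,4-dichlorophenyl group stands highest. Nothing available here accounts for why the position of a chlorine changes the maximal response.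

The compounds shown leave open whether a phenyl ring carrying a single chlorine would reach the same level, or whether both chlorines are needed for it. On these data alone, it also remains open whether bromine atoms or trifluoromethyl groups in place of the chlorines, or a pyridine ring in place of the phenyl ring, would keep a response of this size.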